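Ethoxy for Nitro on the Aryl Ether of a Dithiocarbamate

The source may report more compounds than this note shows. Statements on the series, on what has been measured and on what is new or still open speak of the compounds shown alone.

Compound 1, `O=C1OCC[C@@H]1NC(=S)SCCOc1ccccc1` — in a functional assay on PC-3 cells (Homo sapiens) for antiproliferative activity, read by MTT assay, with a stated time of 72 h (a higher number here means a weaker inhibitor, a lower number a stronger inhibitor), compound 1 gives > 64000 nM, which is a limit of the assay and not a number.
Compound 2, `O=C1OCC[C@@H]1NC(=S)SCCOc1ccccc1Cc1ccccc1` — in this assay compound 2 gives > 64000 nM, again a limit.
Compound 3, `O=C1OCC[C@@H]1NC(=S)SCCOc1ccccc1[N+](=O)[O-]` — in this assay compound 3 gives 24000 nM.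

Going by the values given here, compound 3 therefore stands as the only measured number among the three; compounds 1 and 2 both sit at the limit of > 64000 nM in this assay, at which 2 of the 3 values shown sit. Compound 4, `CCOc1ccccc1OCCSC(=S)N[C@H]1CCOC1=O`, is not yet measured. It differs from compound 3 by ethoxy in place of nitro on an aromatic carbon.

Among the compounds with values here, two measured steps bear on this change, and both run toward the nitro group: an at least 2.6-fold lower number from compound 1 to compound 3 (0.42 log units; beyond the scatter), and an at least 2.6-fold lower number from compound 2 to compound 3 (0.42 log units; beyond the scatter). In each case putting the nitro group onto the aromatic carbon brought the number down out of the limit, while hydrogen and benzyl at that carbon stayed at the limit. The change to compound 4 removes the nitro group again and puts ethoxy in its place, so the reverse direction, a higher number, is expected, with the real chance that only a limit is reported. Compound 4 is thus estimated at 60000 nM, within 20000 nM to 200000 nM. The expected step is a 2.5-fold higher number from compound 3 to compound 4 (0.40 log units; beyond the scatter).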

Compound 4, half-maximal inhibitory concentration: 24100 nM
The estimate for compound 4 lay 2.5-fold (0.40 log units) above the measured number; low and high end bracket the measured number.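

In this assay, nitro and ethoxy on this aromatic carbon cannot be told apart: the exchange gives a 1.0-fold higher number from compound 3 to compound 4 (0.00 log units; within the scatter). The earlier compounds shown here tied a measurable number to the nitro group alone, but ethoxy also gives one, with an at least 2.6-fold lower number from compound 1 to compound 4 (0.42 log units; beyond the scatter) and an at least 2.6-fold lower number from compound 2 to compound 4 (0.42 log units; beyond the scatter). Among the four compounds, nitro and ethoxy at this carbon therefore give numbers, while hydrogen in compound 1 and benzyl in compound 2 leave only a limit: the limit of > 64000 nM in this assay, at which 2 of the 4 values shown sit.

The compounds shown leave open whether an amine, a carboxylic acid or a longer alkoxy chain at this carbon would also give a number. Nor do they show whether nitro or ethoxy would read the same on any other carbon of the aromatic ring.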